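The compounds below may be only part of what the source reports. "The series", "measured", "known", "first", "only" and "open" are said of these compounds alone.

Compound 1 `C=C(C)C(=O)Nc1cccc(-c2nc3ccccc3s2)c1` and compound 2 `O=C(O)/C=C/C(=O)Nc1cccc(-c2nc3ccccc3s2)c1` share one core and differ only in the group attached to the carbonyl carbon. In an ADME assay on HEK293 cells (Homo sapiens) for inhibition, with a stated time of 72 h (on this read-out lower numbers stand for an effect already at smaller amounts and higher numbers for an effect only at larger amounts of compound), compound 1 gives > 25000 nM, which is a limit of the measurement rather than a number. Compound 2 likewise reaches only a limit, > 25000 nM. The step between them, a step that the two limits leave unreadable from compound 1 to compound 2, therefore cannot be read. Compound 1 thus stands at the limit of > 25000 nM in this assay, at which 2 of the 2 values shown sit. Compound 3 `CC(C)(CCl)C(=O)Nc1cccc(-c2nc3ccccc3s2)c1` keeps the same core and alters the same place: 1-(chloromethyl)-1-methylethyl in place of 1-methylethenyl on a carbonyl carbon. Going by the values given here, the single measured step, a step that the two limits leave unreadable from compound 1 to compound 2, touches this place but carries no readable size, so nothing from the measured compounds points to a change in either direction. The expectation for compound 3 is an effect only at large amounts again, with a number no higher from compound 1 to compound 3 (the limit leaves the size open) amounting to no step beyond the scatter. Compound 3 is therefore estimated at 25000 nM, somewhere between 8000 nM and 100000 nM, most probably reported once more as a limit.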

Compound 3, half-maximal effective concentration: > 25000 nM
Compound 3 was reported as a limit (the forecaster's own chance of this, stated with the estimate: 80%); the middle value lies on the limit itself.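

Compound 3 also gives only a limit, so its steps from compound 1 and from compound 2 cannot be read: (the limit of > 25000 nM in this assay, at which 3 of the 3 values shown sit). The compounds shown leave open how far apart the three truly lie, and whether any group on this carbonyl carbon changes the read-out.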